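A few compounds are considered here, and "the series" means these few. Any claim that something is new, unique, unknown or untested is made for them only; others in the source may bear on it.

Of the compounds shown here, two built on a shared core have been measured in a functional assay on MDA-MB-468 cells (Homo sapiens) for antiproliferative activity, read by MTT assay, with a stated time of 24 h; on this read-out lower numbers stand for stronger inhibition and higher numbers for weaker inhibition. Compound 1 `CNC(=O)c1ccccc1Oc1nc(Nc2ccc(Br)cc2)ncc1Br` gives 36600 nM. Compound 2 `CNC(=O)c1ccccc1Oc1nc(Nc2ccc(C)cc2C)ncc1Br` gives 40700 nM in this assay, the highest of the two numbers, with compound 1 nearest. The step of a 1.1-fold higher number from compound 1 to compound 2 (0.05 log units; within the scatter) shows that exchanging one ring for another on a nitrogen on an aromatic ring left the read-out where it was. Compound 3 `CNC(=O)c1ccccc1Oc1nc(Nc2cccc(C(C)C)c2)ncc1Br` has not yet been measured; it differs from compound 2 by 3-isopropylphenyl in place of 2,4-dimethylphenyl on a nitrogen on an aromatic ring. Among the measured compounds shown here, the only measured step that bears on this kind of change is a 1.1-fold higher number from compound 1 to compound 2 (0.05 log units; within the scatter), and it stayed within the scatter, so no step beyond the scatter is expected in this assay. Compound 3 is therefore estimated to give 38000 nM, with a range from 15000 nM to 95000 nM. The step of a 1.1-fold lower number from compound 2 to compound 3 (0.03 log units; within the scatter) that this estimate means is expected to stay within the scatter.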

Compound 3, half-maximal inhibitory concentration: 19500 nM
For compound 3 the middle estimate is 1.9-fold (0.29 log units) above the measured one; the range from low to high includes it.
By their numbers in this assay, from the lowest: compounds 3, 1 and 2 (each within the scatter of the next, the first and the last beyond it).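

The ring on this nitrogen can move the read-out after all: in this assay, the change from 2,4-dimethylphenyl to 3-isopropylphenyl gives a 2.1-fold lower number from compound 2 to compound 3 (0.32 log units; beyond the scatter), a modest step and the first in this series to pass beyond the scatter. The same group set against 4-bromophenyl gives a 1.9-fold lower number from compound 1 to compound 3 (0.27 log units; within the scatter), which stays within the scatter, so compound 3 stands apart from compound 2 only and cannot be called the strongest of the three. Nothing available explains why these rings differ.

As far as these compounds go, whether an amine or a carboxylic acid on this ring would shift the number further remains open. From the compounds shown here alone, it is also open whether a longer chain in place of the isopropyl group, or a simple 3-methylphenyl group, would match compound 3.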